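From Trifluoromethyl to Isopropyl on the Aryl Ring

A few compounds are considered here, and "the series" means these few. Any claim that something is new, unique, unknown or untested is made for them only; others in the source may bear on it.

Compound 1 `Cc1cc(C(=O)O)c(C)n1-c1cccc(Cl)c1`: 430 nM
Compound 2 `Cc1cc(C(=O)O)c(C)n1-c1cccc(C(F)(F)F)c1`: 1500 nM

Both numbers come from an assay on cells for inhibition of Palmitoleoyl-protein carboxylesterase NOTUM variant C330S (Homo sapiens), read by fluorescence, with a stated time of 40 min; a higher number here means a weaker inhibitor, a lower number a stronger inhibitor. Within the data shown here, compound 2 stands highest of the two; the single measured step is a 3.5-fold higher number from compound 1 to compound 2 (0.54 log units; beyond the scatter). Compound 3 `Cc1cc(C(=O)O)c(C)n1-c1cccc(C(C)C)c1` differs from compound 2 by isopropyl in place of trifluoromethyl on an aromatic carbon. Among the measured compounds shown here, no measured step covers an exchange of this kind, and the step from chloro to trifluoromethyl offers no direct guide for it. With nothing pointing firmly either way, only a small change, a 1.5-fold lower number from compound 2 to compound 3 (0.18 log units; within the scatter), is expected, within the usual scatter. Compound 3 is estimated at 1000 nM in this assay, with a range from 300 nM to 3500 nM.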

Compound 3, half-maximal inhibitory concentration: 360 nM
For compound 3 the middle estimate is 2.8-fold (0.44 log units) above the measured one; measured number inside the range.
By their numbers in this assay, from the lowest: compounds 3 and 1 (each within the scatter of the next); then compound 2.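

Replacing trifluoromethyl with isopropyl at this place gives a 4.2-fold lower number from compound 2 to compound 3 (0.62 log units; beyond the scatter), so the weaker result of compound 2 does not extend to every group other than chloro. Isopropyl and chloro cannot be told apart here, with a 1.2-fold lower number from compound 1 to compound 3 (0.08 log units; within the scatter), although one group is built of carbon and the other is a single halogen atom. No available evidence explains this ranking. Going by these compounds, what remains open is how an amine, a methoxy group or a longer alkyl chain would fare at this same place.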